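The source may hold more compounds than are shown below. What is called first, only, known or untested is meant among the compounds shown, and "the series" means these compounds.

Measured so far:
- compound 1 `Cc1cccc(NC(=O)c2ccccc2)n1`: in an assay on membranes from brain for binding affinity to metabotropic glutamate receptor 5 (Rattus norvegicus) (a higher number here means a weaker inhibitor, a lower number a stronger inhibitor), compound 1 gives 35000 nM
- compound 2 `Cc1cccc(NC(=O)c2cccc(C(F)(F)F)c2)n1`: in this assay compound 2 gives 18700 nM

Compound 2 has the lower of these two numbers, but only just: the change from compound 1 to compound 2, trifluoromethyl in place of hydrogen on an aromatic carbon, gave a 1.9-fold lower number from compound 1 to compound 2 (0.27 log units; within the scatter), a difference no larger than repeated measurements of the same compound would show. No order between the two can therefore be claimed.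

Compound 3 `Cc1cccc(NC(=O)c2cccc(OS(C)(=O)=O)c2)n1` continues from compound 2 with one change: (methylsulfonyl)oxy in place of trifluoromethyl on an aromatic carbon. Within the data shown here, the only measured step, a 1.9-fold lower number from compound 1 to compound 2 (0.27 log units; within the scatter), concerns the same position, yet it tells nothing about (methylsulfonyl)oxy itself. With no step beyond the scatter on record, compound 3 is expected to stay close to compound 2 in this assay, with a 1.3-fold higher number from compound 2 to compound 3 (0.13 log units; within the scatter). The estimate for compound 3 is 25000 nM, with a range from 8000 nM to 80000 nM.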

Compound 3, half-maximal inhibitory concentration: 83600 nM
Compound 3: the middle estimate sits 3.3-fold (0.52 log units) below what was measured, and the stated range ends below it.
By their numbers in this assay, from the lowest: compounds 2 and 1 (each within the scatter of the next); then compound 3.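

Among these compounds, this position does respond to what sits on it: in this assay the swap gives a 4.5-fold higher number from compound 2 to compound 3 (0.65 log units; beyond the scatter) and is the first step beyond the scatter. Measured against plain hydrogen, (methylsulfonyl)oxy also gives a 2.4-fold higher number from compound 1 to compound 3 (0.38 log units; beyond the scatter) as a modest change, so compound 3 is the weakest inhibitor of the three, and this group, which brings hydrogen-bond acceptors where trifluoromethyl has none, is not tolerated as well as either alternative. No measurement on hand explains this loss of binding.

From the compounds shown here alone, whether an amine, a carboxylic acid or a methoxy group on this carbon would stay close to compound 2 or fall with compound 3 remains open. Also open, going by these compounds, is whether (methylsulfonyl)oxy would have the same effect on another carbon of this ring.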